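A few compounds are considered here, and "the series" means these few. Any claim that something is new, unique, unknown or untested is made for them only; others in the source may bear on it.

Compound 3 `Cc1nn(C)c(Oc2cccc(F)c2F)c1/C=N\CCCCCCOc1cc2oc(=O)cc(C)c2cc1Cl` belongs to a small series built on a shared core that carries an aryloxy group on a pyrazole and a six-carbon chain to a chlorinated coumarin ether. In a functional assay on U-87MG ATCC cells for antiproliferative activity against U-87 MG (Homo sapiens), read by MTT assay, with a stated time of 72 h (on this read-out lower numbers stand for stronger inhibition and higher numbers for weaker inhibition), compound 3 gives > 25000 nM, which is a limit of the assay rather than a number. Compound 4 `Cc1nn(C)c(Oc2cccc(C(F)(F)F)c2)c1/C=N\CCCCCCOc1cc2oc(=O)cc(C)c2cc1Cl` keeps everything else and differs only in 3-(trifluoromethyl)phenyl in place of 2,3-difluorophenyl on an oxygen on an aromatic ring.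

Among the measured compounds, only one comparable change has a numerical outcome. Compound 1 `Cc1nn(C)c(Oc2cccc(F)c2)c1/C=N\CCCCCOc1cc2oc(=O)cc(C)c2cc1Cl` gives 9870 nM in this assay. Compound 2 `Cc1nn(C)c(Oc2ccc(I)cc2)c1/C=N\CCCCCOc1cc2oc(=O)cc(C)c2cc1Cl` gives > 25000 nM, a limit of the assay. The step of an at least 2.5-fold higher number from compound 1 to compound 2 (0.40 log units; beyond the scatter) therefore shows that exchanging the aryl group on the aryloxy oxygen can push the number past the limit, and the limit of > 25000 nM in this assay, at which 2 of the 3 values shown sit, shows that two of the three known values sit there. Among the compounds with values here, no step connects the 2,3-difluorophenyl to the 3-(trifluoromethyl)phenyl group directly, and compound 3 starts from a limit, so the direction of an at least 1.2-fold lower number from compound 3 to compound 4 (0.09 log units; that floor lies within the scatter) can only be estimated loosely; a number near or at the limit is expected. Compound 4 is estimated at 20000 nM, within 6000 nM to 60000 nM.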

Compound 4, half-maximal inhibitory concentration: 23400 nM
Compound 4: middle estimate off by 1.2-fold (0.07 log units), on the low side; the range from low to high includes it.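

Compound 4 gives 23400 nM in this assay, the first number rather than a limit for a compound with the chain of compound 3, so a 3-(trifluoromethyl)phenyl group on this oxygen keeps the read-out within the measurable range. The value of compound 3 is a limit and not a number, and the step read from it is an at least 1.0-fold lower number from compound 3 to compound 4 (0.02 log units; that floor lies within the scatter), so the exchange of 2,3-difluorophenyl for 3-(trifluoromethyl)phenyl shows no change that can be told apart from the usual scatter. Neither group brings this chain to a clearly lower number, and the read-out remains crowded at the top of its range: the limit of > 25000 nM in this assay, at which 2 of the 4 values shown sit.

The compounds shown leave open whether a phenyl ring carrying an amine or a carboxylic acid in place of these halogen-bearing groups would give a number lower than that of compound 1, at 9870 nM. They also leave open how 3-fluorophenyl or 3-(trifluoromethyl)phenyl would behave if only the chain were changed, whether to a shorter chain or a longer chain.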